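This account rests on a few compounds, and the source may have more. Where it says the series, first, only, none or still open, it means among the compounds named here.

Four compounds that share one core are compared in a functional assay on thoracic aorta for antagonist activity at thromboxane A2 receptor (Rattus norvegicus); on this read-out higher numbers stand for weaker inhibition and lower numbers for stronger inhibition. Compound 1 `CC(C)c1ccc2c(CCCCS(=O)(=O)Nc3ccc(Cl)cc3)cc(C(=O)O)c-2cc1` carries a carboxy group on the five-membered ring of that core, and in this assay compound 1 gives 2600 nM. Compound 2 `CC(C)c1ccc2c(CCCCS(=O)(=O)Nc3ccc(Cl)cc3)cc(S(=O)(=O)O)c-2cc1` differs from it in a single place: sulfo in place of carboxy on an aromatic carbon. In this assay compound 2 gives 220 nM. Among the compounds with values here, the single change therefore produced a 12-fold lower number from compound 1 to compound 2 (1.07 log units; beyond the scatter), a step large enough to stand clearly apart from run-to-run noise.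

Compound 3 `CC(C)c1ccc2c(CCCC(=O)NS(=O)(=O)c3ccccc3)cc(C(=O)O)c-2cc1` carries a different side chain; how its core differs from the core of compound 1 is not broken down here. In this assay compound 3 gives only a limit, > 100000 nM, which is not a measured number. This is the limit of > 100000 nM in this assay, at which 1 of the 3 values shown sits, so the true value of compound 3 could lie anywhere beyond it.

Compound 4 `CC(C)c1ccc2c(CCCC(=O)NS(=O)(=O)c3ccccc3)cc(S(=O)(=O)O)c-2cc1` stands to compound 3 exactly as compound 2 stands to compound 1: sulfo in place of carboxy on an aromatic carbon. The surroundings of the changed position are the same in both pairs, so this is the same kind of change. Compound 4 is therefore expected to land near 20000 nM, within a range of 4000 nM to 150000 nM. The expected step is an at least 5.0-fold lower number from compound 3 to compound 4 (0.69 log units; beyond the scatter), which rests on a 12-fold lower number from compound 1 to compound 2 (1.07 log units; beyond the scatter); a starting point that is itself only a limit leaves the landing point of compound 4 wide open, and a second limit is quite possible.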

Compound 4, half-maximal inhibitory concentration: 65000 nM
Compound 4: middle estimate off by 3.3-fold (0.51 log units), on the low side; the range from low to high includes it.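

In this assay sulfo in place of carboxy on an aromatic carbon gives an at least 1.5-fold lower number from compound 3 to compound 4 (0.18 log units; that floor lies within the scatter) on the second core. Compound 3 has the limit > 100000 nM and not a measured number, so this step is a floor and not a measured size. The result is compatible with the change carrying over from one core to the other, but it does not show that the change carries over with the same size, or that the two cores respond differently: the same change on two cores in this assay, a 12-fold lower number (1.07 log units; beyond the scatter) from compound 1 to compound 2 and an at least 1.5-fold lower number (0.18 log units; that floor lies within the scatter) from compound 3 to compound 4; the limit leaves it open whether they differ

Going by these compounds, only carboxy and sulfo appear at this position on the five-membered aromatic ring, so it remains open how other acid groups placed there, such as a phosphonic acid or a tetrazole, would compare with them on either core. Only two side chains appear as well, which leaves open whether the same change would give a similar step with a shorter or longer chain, or with an amine in that chain.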